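The compounds below may be only part of what the source reports. "The series", "measured", "known", "first", "only" and "open" are said of these compounds alone.

Measured compounds:
compound 1 `C/C(=C\COC(=O)Nc1ccccc1)C1=CC(=O)C(C)(C)O1`: in a functional assay on MOLT-4F cells (Homo sapiens) for inhibition (a lower number here means a stronger inhibitor, a higher number a weaker inhibitor), compound 1 gives only a limit, > 200 ug/mL.
compound 2 `C/C(=C\COC(=O)NC(C)(C)C)C1=CC(=O)C(C)(C)O1`: in this assay compound 2 gives 6.1 ug/mL.

For the measured compounds named here, compound 2 thus holds the only number in this assay; the other value shown is a limit. Compound 3 `C/C(=C\COC(=O)NC(C)C)C1=CC(=O)C(C)(C)O1` differs from compound 2 by hydrogen in place of methyl on a saturated chain carbon bound to an amide-type nitrogen and two saturated chain carbons, read one bond further out as tert-butyl to isopropyl. Going by the values given here, the single measured step, an at least 32-fold lower number from compound 1 to compound 2 (1.51 log units; beyond the scatter), exchanged phenyl for tert-butyl and was large, but no measured step removes one methyl from that chain carbon. The step to compound 3 is expected to be small, a 1.6-fold higher number from compound 2 to compound 3 (0.21 log units; within the scatter). Compound 3 is therefore estimated at 10 ug/mL, with a range from 3 ug/mL to 35 ug/mL.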

Compound 3, half-maximal inhibitory concentration: 6.6 ug/mL
For compound 3 the middle estimate is 1.5-fold (0.18 log units) above the measured one; the measured number falls inside the stated range.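

In this assay, cutting tert-butyl back to isopropyl on the chain carbon leaves the number in place (a 1.1-fold higher number from compound 2 to compound 3 (0.03 log units; within the scatter)), so the third methyl on that carbon is not needed at this level of inhibition. Isopropyl also keeps the large difference from phenyl (an at least 30-fold lower number from compound 1 to compound 3 (1.48 log units; beyond the scatter)), which therefore does not depend on the full tert-butyl group. That difference is open on one side, as compound 1 gives only a limit: the limit of > 200 ug/mL in this assay, at which 1 of the 3 values shown sits.

As far as these compounds go, whether ethyl, cyclohexyl or benzyl on the nitrogen would hold this level remains open.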